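A Shorter Saturated Tail on Compound 3

The source may report more compounds than this note shows. Statements on the series, on what has been measured and on what is new or still open speak of the compounds shown alone.

Three anilides of a long fatty acid have been measured in an assay on microsomes from intestine for inhibition of acyl-CoA:cholesterol acyltransferase (Oryctolagus cuniculus); a lower number here means a stronger inhibitor, a higher number a weaker inhibitor. Compound 1 `CCCCCCCC/C=C/CCCCCCCC(=O)Nc1ccccc1C(C)C` gives 600 nM. Compound 2 `CCCCCCCC/C=C/CCCCCCCC(=O)Nc1cc(C(=O)OC)ccc1OC` gives 430 nM in this assay. Compound 3 `CCCCCCCC/C=C/CCCCCCC(C)(C)C(=O)Nc1c(OC)cc(OC)cc1OC` gives 44 nM, the lowest of the three numbers; compound 2 is the nearest to it and compound 1 the furthest, and both gaps lie beyond the usual scatter. No two of the measured compounds differ in only one place, so none of these gaps can be read as a single structural step.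

Compound 4 `CCCCCCCCCCCCCCC(C)(C)C(=O)Nc1c(OC)cc(OC)cc1OC` keeps the shared core and the amide of compound 3 and differs from it in one place: a group of 8 heavy atoms (8 carbon; no ring) in place of a group of 10 heavy atoms (10 carbon; no ring), on a saturated chain carbon, seven bonds along the chain from a carbonyl carbon. Among the measured compounds shown here, the measured set holds no step of this kind, so the data give no direction for it. The step of a 1.6-fold higher number from compound 3 to compound 4 (0.20 log units; within the scatter) is expected to be small, most likely within the usual scatter, with a slight lean toward a higher number. For compound 4 the expected value in this assay is 70 nM, with a range from 25 nM to 200 nM, resting on the value of compound 3 alone.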

Compound 4, half-maximal inhibitory concentration: 44 nM
Estimate against measurement, compound 4: 1.6-fold (0.20 log units) above, and the stated range covers the measured number.
By their numbers in this assay, from the lowest: compounds 3 and 4 (each within the scatter of the next); then compounds 2 and 1 (each within the scatter of the next).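

In this assay, among the compounds shown here, replacing the group of 10 heavy atoms, with its double bond, by octyl on this saturated chain carbon, seven bonds along the chain from a carbonyl carbon, gives no change at the digits printed from compound 3 to compound 4 (within the scatter), the first step in the set that can be read as one change. For the compounds shown here, it shows that at this position, on the core of compound 3, the tail can lose its double bond and take the smaller octyl group with no measurable shift in the number, something the earlier compounds, which differed in more than one place, could not show. No measurement accompanies this result that would explain why the number holds.

Going by these compounds alone, the step combines two alterations, so the part played by the double bond and the part played by chain length cannot be separated, and a saturated chain matching the length of the one in compound 3, a longer chain, a much shorter chain such as butyl, or a chain ending in a carboxylic acid could each answer differently. As far as these compounds go, whether octyl would act the same way on the cores of compound 1 and compound 2 also remains open.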